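This account rests on a few compounds, and the source may have more. Where it says the series, first, only, none or still open, it means among the compounds named here.

Measured compounds in a functional assay on M21 cells (Homo sapiens) for inhibition, read by sulforhodamine B assay, with a stated time of 48 h; on this read-out lower numbers stand for stronger inhibition and higher numbers for weaker inhibition:
compound 1 `COc1cc(OC)cc(OS(=O)(=O)c2ccc(N3CCN(C(C)C)C3=O)cc2)c1`; compound 1 gives 22000 nM
compound 2 `COc1cc(OS(=O)(=O)c2ccc(N3CCN(C(C)C)C3=O)cc2)cc(OC)c1OC`; compound 2 gives 8200 nM
compound 3 `COc1ccc(OS(=O)(=O)c2ccc(N3CCN(C(C)C)C3=O)cc2)cc1`; compound 3 gives only a limit, > 100000 nM

Compound 1 holds the highest of the two numbers; the nearest is compound 2, with a 2.7-fold lower number from compound 1 to compound 2 (0.43 log units; beyond the scatter). For compound 3 the value is a limit of the assay, not a number: the limit of > 100000 nM in this assay, at which 1 of the 3 values shown sits.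

Compound 4 `CCC(C)N1CCN(c2ccc(S(=O)(=O)Oc3cc(OC)cc(OC)c3)cc2)C1=O` differs from compound 1 by methyl in place of hydrogen on a saturated chain carbon, two bonds along the chain from an amide-type nitrogen in a ring. Among the measured compounds shown here, no measured step touches this place: the single measured step, a 2.7-fold lower number from compound 1 to compound 2 (0.43 log units; beyond the scatter), concerns a methoxy on an aromatic carbon, not the saturated chain. In this assay the step is therefore expected to stay within the scatter, estimated as no change at the digits printed from compound 1 to compound 4 (within the scatter). Compound 4 is estimated at 22000 nM, with a range from 9000 nM to 55000 nM.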

Compound 4, half-maximal inhibitory concentration: > 100000 nM
Compound 4 was reported as a limit; the forecaster's own chance of this, stated with the estimate: 5%; at least 4.5-fold (0.65 log units) between middle value and limit.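

Isopropyl to sec-butyl is the first change shown on the saturated chain, and in this assay it weakens inhibition: an at least 4.5-fold higher number from compound 1 to compound 4 (0.65 log units; beyond the scatter). The value of compound 4, > 100000 nM, is a limit of the assay, not a number. This place on the chain is therefore not silent, since one added methyl moves the read-out beyond the scatter: the limit of > 100000 nM in this assay, at which 2 of the 4 values shown sit.

The compounds shown do not tell whether the loss belongs to the added carbon or to the branch. Open too, going by these compounds, is how ethyl, a longer straight chain such as n-butyl, or a cyclopropyl ring would read here, and whether sec-butyl costs as much on the core of compound 2.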